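Acetyl-to-phenyl swap on the piperazine of compound 3

A few compounds are considered here, and "the series" means these few. Any claim that something is new, unique, unknown or untested is made for them only; others in the source may bear on it.

Among the measured compounds shown here, compound 3 `CC(=O)N1CCN(C(=O)Cn2c(-c3ccc(Cl)cc3)csc2=N)CC1` gives 11300 nM in an assay on isolated protein for inhibition of Thymidylate synthase (Homo sapiens) (a lower number here means a stronger inhibitor, a higher number a weaker inhibitor), and so holds the highest of the three numbers measured so far. For the measured compounds named here, compound 1 `N=c1scc(-c2ccccc2)n1CC(=O)N1CCOCC1` gives 6220 nM in this assay, and compound 2 `CC(=O)N1CCN(C(=O)Cn2c(-c3ccc(C)cc3)csc2=N)CC1` gives 3650 nM; the sole single-point step measured, a 3.1-fold higher number from compound 2 to compound 3 (0.49 log units; beyond the scatter), concerns chloro in place of methyl on the aromatic carbon and says nothing about the amide end of the molecule.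

Compound 4 `N=c1scc(-c2ccc(Cl)cc2)n1CC(=O)N1CCN(c2ccccc2)CC1` carries phenyl in place of acetyl on an amine nitrogen in a ring. Going by the values given here, no measured step bears on this change: compound 1 differs from compound 3 in two places at once, and the step between compound 2 and compound 3 touches another part of the structure. An expectation for compound 4 can therefore only lean on the span the three numbers already cover, with no direction favoured. Compound 4 is estimated at 8000 nM in this assay, within 2500 nM to 25000 nM; the expected step of a 1.4-fold lower number from compound 3 to compound 4 (0.15 log units; within the scatter) is judged to stay within the scatter.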

Compound 4, inhibition constant: 5090 nM
Compound 4: middle estimate off by 1.6-fold (0.20 log units), on the high side; the measured number falls inside the stated range.
By their numbers in this assay, from the lowest: compounds 2, 4, 1 and 3 (each within the scatter of the next, the first and the last beyond it).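

On an amine nitrogen in a ring, the amide end of the series responds in this assay to a change of group: phenyl in place of acetyl gives a 2.2-fold lower number from compound 3 to compound 4 (0.35 log units; beyond the scatter), a modest step beyond the scatter. Among the compounds shown here, the only earlier single-place step concerned an aromatic carbon at the other end of the molecule, so this is the first reading at this position. It shows that the acetyl, with its carbonyl and hydrogen-bond acceptor, can give way to a six-membered aromatic ring of carbon only without the number rising. Nothing at hand accounts for the size or direction of this step.

As far as these compounds go, a benzyl or a simple methyl on the same nitrogen remains open, so it is unclear whether the aromatic ring itself matters here. Also open, from the compounds shown here alone, is whether the phenyl step holds when methyl replaces chloro on the aromatic carbon, as in compound 2.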